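Aryl hydrazone swap on the shared core: compound 4

The source may report more compounds than this note shows. Statements on the series, on what has been measured and on what is new or still open speak of the compounds shown alone.

Three analogues on a common core have been examined in a functional assay on PC-3 cells (Homo sapiens) for antiproliferative activity, read by MTT assay, with a stated time of 72 h; a lower number here means a stronger inhibitor, a higher number a weaker inhibitor. Compound 1 `O=C(N/N=C/c1cccc([N+](=O)[O-])c1)Nc1ccc(Oc2ccnc3[nH]ccc23)c(F)c1` gives 5140 nM, the lowest of the two numbers obtained. Compound 3 `CC(C)(C)c1cc(/C=N/NC(=O)Nc2ccc(Oc3ccnc4[nH]ccc34)c(F)c2)cc(C(C)(C)C)c1O` gives 10400 nM in this assay, a higher number than compound 1, and the gap between the two lies beyond the usual scatter. Compound 2 `COc1cc(/C=N/NC(=O)Nc2ccc(Oc3ccnc4[nH]ccc34)c(F)c2)cc(OC)c1OC` gives "not active" (no number reported) in this assay, so no number is available for it. Among the compounds with values here, no pair of measured compounds differs in a single place, so no single step is established.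

Compound 4 `O=C(N/N=C/c1cc(Br)c(O)c(Br)c1)Nc1ccc(Oc2ccnc3[nH]ccc23)c(F)c1` differs from compound 1 in one place: 3,5-dibromo-4-hydroxyphenyl in place of 3-nitrophenyl on a carbon with a double bond to nitrogen. Among the measured compounds, the entry that also carries a phenol, compound 3, gives 10400 nM in this assay, while the trimethoxy analogue compound 2 gives "not active" (no number reported). On that basis a small step in this assay, toward a higher number or none beyond the scatter, is expected from compound 1 to compound 4, with a 1.3-fold higher number from compound 1 to compound 4 (0.10 log units; within the scatter) as the working estimate. Compound 4 is therefore estimated at 6500 nM in this assay, within a range from 2500 nM to 18000 nM.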

Compound 4, half-maximal inhibitory concentration: "not active" (no number reported)
No number was reported for compound 4; no gap can be computed for the estimate.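

Within the data shown here, compound 4 carries no number in this assay, so no step from compound 1 to compound 4 can be read, and no available data bear on this result. The compounds shown leave open how far the aryl group on the hydrazone governs activity on the shared core.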